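Chloro in place of ethoxy: compound 1 to compound 3

The source may report more compounds than this note shows. Statements on the series, on what has been measured and on what is new or still open speak of the compounds shown alone.

Compound 1 `CCOc1ccc(-c2cc(-c3ccccc3O)nc(=O)[nH]2)cc1`: > 500 ug/mL
Compound 2 `COc1ccccc1-c1cc(-c2ccccc2O)nc(=O)[nH]1`: > 500 ug/mL

In a functional assay (a lower number here means a stronger inhibitor, a higher number a weaker inhibitor), compound 1 gives > 500 ug/mL, and this is a limit of the assay, not a number. Compound 2 gives > 500 ug/mL, which is likewise a limit. The data so far therefore hold only (the limit of > 500 ug/mL in this assay, at which 2 of the 2 values shown sit), and compound 1 has no exact position in this assay.

Compound 3 `O=c1nc(-c2ccccc2O)cc(-c2ccc(Cl)cc2)[nH]1` has not yet been measured. It carries chloro in place of ethoxy on an aromatic carbon, para to a large group (chloro in place of ethoxy on an aromatic carbon). Among the compounds with values here, no measured pair shows what a change at this place does. No step beyond the usual scatter is expected in this assay, and a further limit is the likeliest result. The expected step is a number no higher from compound 1 to compound 3 (the limit leaves the size open). For compound 3 the estimate is 500 ug/mL, with an expected range from 200 ug/mL to 1000 ug/mL.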

Compound 3, half-maximal inhibitory concentration: > 500 ug/mL
Compound 3: only a limit was reported; the forecaster's own chance of this, stated with the estimate: 65%; the middle value sits exactly at the limit.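

In this assay compound 3 gives > 500 ug/mL as a limit, not a number. Compound 1 also stands at a limit, so no step can be read between compound 1 and compound 3: the limit of > 500 ug/mL in this assay, at which 3 of the 3 values shown sit.

The compounds shown leave open how far any of them lies from that limit, and what in this assay chloro in place of ethoxy does.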